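The compounds below may be only part of what the source reports. "The series", "measured", "known", "first", "only" and "open" are said of these compounds alone.

Compound 1 `CC(=O)Nc1ccc(S(=O)(=O)NNc2ccc(C)cc2)cc1`, 1170 nM; compound 2 `COc1ccc(NNS(=O)(=O)c2ccc(NC(C)=O)cc2)cc1`, > 10000 nM.

In an assay on HeLa cells for inhibition of Indoleamine 2,3-dioxygenase 1 (Homo sapiens), read by spectrophotometry, with a stated time of 24 h (on this read-out higher numbers stand for an effect only at larger amounts of compound and lower numbers for an effect already at smaller amounts), compound 2 shows a limit of the assay, not a number: it gives > 10000 nM. Compound 2 thus stands at the weak end of the two values seen, (the limit of > 10000 nM in this assay, at which 1 of the 2 values shown sits). Within the data shown here, the one measured step, an at least 8.5-fold higher number from compound 1 to compound 2 (0.93 log units; beyond the scatter), went the same way. Compound 3 `CC(=O)Nc1ccc(S(=O)(=O)NNc2ccc(S(N)(=O)=O)cc2)cc1` differs from compound 2 by sulfamoyl in place of methoxy on an aromatic carbon. Among the measured compounds shown here, no measured step bears directly on this exchange; the step from compound 1 to compound 2 tells only that a change at this position can move the read-out beyond the scatter, not which way sulfamoyl will move it. Starting from a limit, the expected step of an at least 1.4-fold lower number from compound 2 to compound 3 (0.15 log units; that floor lies within the scatter) is therefore uncertain in size and direction. Compound 3 is estimated at 7000 nM, within a range from 1500 nM to 30000 nM, with a fair chance that only a limit is reported again.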

Compound 3, half-maximal effective concentration: 3120 nM
For compound 3 the middle estimate is 2.2-fold (0.35 log units) above the measured one; the range from low to high includes it.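

In this assay the exchange of methoxy for sulfamoyl, para to a large group, gives an at least 3.2-fold lower number from compound 2 to compound 3 (0.50 log units; beyond the scatter) and shows that a measurable effect survives at this position with a group of 4 heavy atoms, so the loss seen with methoxy does not extend to every replacement of methyl. Sulfamoyl does not match methyl, however: the exchange gives a 2.7-fold higher number from compound 1 to compound 3 (0.43 log units; beyond the scatter) and leaves compound 1 with the lowest number of the three. Compound 2 gives a limit, not a number, so the step leading away from it has only a floor: the limit of > 10000 nM in this assay, at which 1 of the 3 values shown sits.

The compounds shown leave open how an amine, a carboxylic acid or a chlorine atom would read at this same position. They also leave open whether a methylsulfonyl group would read like sulfamoyl.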